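Two changes on one core, read in a cell-killing test

A few compounds are considered here, and "the series" means these few. Any claim that something is new, unique, unknown or untested is made for them only; others in the source may bear on it.

Compound 1 `CN(Cc1ccccc1)C(=O)c1ccc(-c2cc(C3=CC(=O)C=CC3=O)no2)s1` gives 11000 nM in a functional assay on PC-3 cells (Homo sapiens) for cytotoxicity, read by XTT assay, with a stated time of 72 h; on this read-out lower numbers stand for stronger inhibition and higher numbers for weaker inhibition. Compound 2 `COc1ccc(OC)c(-c2cc(-c3ccc(C(=O)N(C)Cc4ccccc4)s3)on2)c1` reaches only the limit of this assay, > 30000 nM. Compound 3 `CN(Cc1ccc(F)cc1)C(=O)c1ccc(-c2cc(C3=CC(=O)C=CC3=O)no2)s1` likewise reaches only the limit, > 30000 nM.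

Two of the three values thus sit at the same limit, (the limit of > 30000 nM in this assay, at which 2 of the 3 values shown sit). From compound 1 to compound 2 the change is a group of 10 heavy atoms (8 carbon, 2 oxygen; one six-membered aromatic ring of carbon only) in place of a group of 8 heavy atoms (6 carbon, 2 oxygen; one six-membered non-aromatic ring of carbon only), on an aromatic carbon, and it made an at least 2.7-fold higher number from compound 1 to compound 2 (0.43 log units; beyond the scatter). The cores of compound 1 and compound 3 differ by fluoro in place of hydrogen on an aromatic carbon, and that step is an at least 2.7-fold higher number from compound 1 to compound 3 (0.43 log units; beyond the scatter).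

Compound 4 `COc1ccc(OC)c(-c2cc(-c3ccc(C(=O)N(C)Cc4ccc(F)cc4)s3)on2)c1` has not been measured in this assay. It differs from compound 3 by a group of 10 heavy atoms (8 carbon, 2 oxygen; one six-membered aromatic ring of carbon only) in place of a group of 8 heavy atoms (6 carbon, 2 oxygen; one six-membered non-aromatic ring of carbon only), on an aromatic carbon, the same change as between compound 1 and compound 2, at the same place. Compound 3 already gives only the limit > 30000 nM. The expected step is a step that the limit leaves unreadable from compound 3 to compound 4, and this expectation rests on an at least 2.7-fold higher number from compound 1 to compound 2 (0.43 log units; beyond the scatter) seen earlier for the same change. Compound 4 is therefore expected to give 60000 nM, most likely again only a limit, somewhere between 25000 nM and 200000 nM.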

Compound 4, half-maximal inhibitory concentration: > 30000 nM
Compound 4: no number, only a limit; the forecaster's own chance of this, stated with the estimate: 85%; the middle value does not contradict the limit.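

Compound 4 gives > 30000 nM, which is a limit and not a number. Its steps from compound 2 and from compound 3 cannot be read, since those compounds also end at a limit: the limit of > 30000 nM in this assay, at which 3 of the 4 values shown sit.

The compounds shown leave open what the true values of compound 2, compound 3 and compound 4 are, and whether fluoro changes anything when 2,5-dimethoxyphenyl is present.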